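Extending a Methyl into a Hydroxypropyl Side Chain

This account rests on a few compounds, and the source may have more. Where it says the series, first, only, none or still open, it means among the compounds named here.

Of the compounds shown here, three sharing one core have been measured in an assay on NK92 cells for inhibition of interleukin-15 (Homo sapiens), read by AlphaScreen, with stated times of 30 min and 1 h; a higher number here means a weaker inhibitor, a lower number a stronger inhibitor. Compound 1 `Cn1c(Cc2nn(C)c(=O)c3ccccc23)nnc1SCC(=O)Nc1ccc(Cl)cc1Cl` gives 4500 nM. Compound 2 `CCOC(CCn1c(Cc2nn(C)c(=O)c3ccccc23)nnc1SCCCCCCCC(=O)Nc1ccc(Cl)cc1Cl)OCC` gives 30000 nM, and compound 3 `Cn1nc(Cc2nnc(SCCCCCCCC(=O)Nc3ccc(Cl)cc3Cl)n2CCC=O)c2ccccc2c1=O` gives 710 nM. Among these three numbers compound 1 stands second highest: it lies well above compound 3 and well below compound 2, and both gaps are beyond the scatter.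

Compound 4 `Cn1nc(Cc2nnc(SCC(=O)Nc3ccc(Cl)cc3Cl)n2CCCO)c2ccccc2c1=O` differs from compound 1 by 2-hydroxyethyl in place of hydrogen on a saturated chain carbon bound to an aromatic nitrogen; seen one bond further out, a methyl becomes a 3-hydroxypropyl. For the measured compounds named here, the only measured step at this position is a 42-fold lower number from compound 2 to compound 3 (1.63 log units; beyond the scatter), where the end of an existing chain was exchanged rather than a chain added, so it bears on compound 4 only loosely; what it does show is that the group at the end of this chain can shift the result a great deal. Compound 3, which also carries a longer chain at this position, gives a lower number than compound 1, but the two differ elsewhere as well, so no clean step can be read from them. A modest improvement is therefore expected, a 1.8-fold lower number from compound 1 to compound 4 (0.26 log units; within the scatter), with wide uncertainty. Compound 4 is expected to give 2500 nM, within a range from 600 nM to 10000 nM.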

Compound 4, half-maximal inhibitory concentration: > 30000 nM
Compound 4: a limit, no number; the forecaster's own chance of this, stated with the estimate: 10%; middle value at least 12-fold (1.07 log units) from the limit.
By their numbers in this assay, from the lowest: compound 3; then compound 1; then compound 2.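

In this assay, the reading for compound 4 is a limit of the assay and not a number: the limit of > 30000 nM in this assay, at which 1 of the 4 values shown sits. Even with only a limit, the direction of the change is clear, with an at least 6.6-fold higher number from compound 1 to compound 4 (0.82 log units; beyond the scatter), so replacing methyl with 3-hydroxypropyl on the shared core makes the number higher, not lower. The earlier step at this position exchanged only the end of an existing chain, whereas this one adds the chain itself, and it shows that this addition alone is enough to move the result by more than the usual scatter.

On these data alone, what remains open is whether the length of the chain or the hydroxyl at its end accounts for the higher number, since a plain propyl group or a 3-aminopropyl chain in the same place on the core of compound 1 would help to separate the two. Also open, as far as these compounds go, is whether a shorter chain, such as ethyl or 2-hydroxyethyl bound directly to the aromatic nitrogen, would be tolerated better than the 3-hydroxypropyl chain of compound 4.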